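This account rests on a few compounds, and the source may have more. Where it says the series, first, only, none or still open, it means among the compounds named here.

Measured in a functional assay on NCI-H1993 cells (Homo sapiens) for inhibition, read by CCK-8 assay, with a stated time of 72 h; on this read-out higher numbers stand for weaker inhibition and lower numbers for stronger inhibition:
- compound 1 `Cn1cc(-c2cnc3nc(O)n(Cc4ccc5ncccc5c4)c3n2)cn1`: > 10000 nM
- compound 2 `CCC(c1cc2cccnc2cc1F)n1cnc2ncc(-c3ccncc3)nc21`: "not determined" (no result reported)
- compound 3 `c1cnc2ccc(Cn3cnc4ncc(-c5cn[nH]c5)nc43)cc2c1`: 2890 nM

The entry for compound 1, > 10000 nM, is a limit of the assay and not a number. Among the compounds with values here, compound 2 has no result, so compound 3, at 2890 nM, holds the only actual number in this small set.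

The next compound to be tested is compound 4 `Nc1ccc(-c2cnc3ncn(Cc4ccc5ncccc5c4)c3n2)cc1`. It has 4-aminophenyl in place of 1H-pyrazol-4-yl on an aromatic carbon of the shared core: 4-aminophenyl in place of 1H-pyrazol-4-yl on an aromatic carbon.

Within the data shown here, no two measured compounds differ in one place only, so the data show nothing about how large such a swap tends to be in this assay. Among the measured compounds shown here, the only anchor is compound 3 at 2890 nM, and no shift beyond the usual scatter is expected, in either direction. The expected change is a 1.2-fold lower number from compound 3 to compound 4 (0.06 log units; within the scatter), and it is uncertain. The estimate for compound 4 is 2500 nM, with an expected range from 500 nM to 10000 nM.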

Compound 4, half-maximal inhibitory concentration: 4950 nM
Compound 4: the middle estimate sits 2.0-fold (0.30 log units) below what was measured; low and high end bracket the measured number.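

In this assay, putting 4-aminophenyl in place of 1H-pyrazol-4-yl on an aromatic carbon of the shared core gives a 1.7-fold higher number from compound 3 to compound 4 (0.23 log units; within the scatter). On this read-out the two compounds cannot be told apart, so at this position a six-membered aromatic ring of carbon only can stand in for a five-membered aromatic ring with 2 hetero atoms without a shift beyond normal scatter. Compound 1 remains the only compound shown that sits at a limit, which is not a number: the limit of > 10000 nM in this assay, at which 1 of the 4 values shown sits.

As far as these compounds go, whether the amino group on the new ring contributes anything stays open, since plain phenyl would be needed for that comparison. It is also unknown how a carboxylic acid or a longer chain at this position would read in this assay.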